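The source may report more compounds than this note shows. Statements on the series, on what has been measured and on what is new or still open speak of the compounds shown alone.

Compound 1 `CC(C)=CCOc1c(C)c(C)c2c(c1C)CCC(C)(COc1ccc(/C=C3\SC(=O)NC3=O)cc1F)O2` carries a fluoro group. In a functional assay on MCF7 cells (Homo sapiens), tested at 2.5 uM (a lower number here means a stronger effect, a higher number a weaker effect of the compound at the concentration tested), compound 1 gives 95%, the highest of the two numbers in hand, although compound 2 `Cc1c(C)c2c(c(C)c1OC/C=C/c1ccccc1)CCC(C)(COc1ccc(/C=C3\SC(=O)NC3=O)cc1)O2`, which gives 92% in this assay, lies within the scatter of compound 1, so the two cannot be put in order. Compound 3 `CC(C)=CCOc1c(C)c(C)c2c(c1C)CCC(C)(COc1ccc(/C=C3\SC(=O)NC3=O)cc1Br)O2` differs from compound 1 in one place: bromo in place of fluoro on an aromatic carbon. Going by the values given here, no step between measured compounds is available to gauge such a change, and the two measured values sit close together, both pointing to a weak effect at the concentration tested. Compound 3 is therefore expected to show much the same weak effect, and the step of a number 2 percentage points lower from compound 1 to compound 3 (within the scatter) is expected to be small, falling within the scatter in either direction. Compound 3 is estimated at 93% in this assay, in the range 80% to 105%.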

Compound 3, a percentage reported as activity, at one concentration (the size of the read-out at that concentration, not a potency): 96%
The estimate for compound 3 lay 3 percentage points below the measured number; the range from low to high includes it.
By their numbers in this assay, from the lowest: compounds 2, 1 and 3 (each within the scatter of the next).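

In this assay, bromo in place of fluoro on an aromatic carbon, ortho to a large group, gives a number 1 percentage points higher from compound 1 to compound 3 (within the scatter) and so leaves compound 1 and compound 3 without an order. Going by these compounds alone, this is the first step read at this position: one halogen replaces another, each a single heavy atom with no hydrogen-bond donors or acceptors, and the weak effect at the concentration tested stays in place. Nothing at hand gives a reason for this result.

The compounds shown leave open whether this position can move the read-out at all, since both groups seen here are halogens. An amine, a carboxylic acid or a longer chain at this aromatic carbon could show whether a group of another kind gives a stronger effect on the same core.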